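Bromo to Chloro in the Nitro Compound

A few compounds are considered here, and "the series" means these few. Any claim that something is new, unique, unknown or untested is made for them only; others in the source may bear on it.

In a functional assay on T98G cells (Homo sapiens) for inhibition, read by MTT assay, with a stated time of 72 h (on this read-out lower numbers stand for stronger inhibition and higher numbers for weaker inhibition), compound 1 `CC1(C)CC(NC(=S)Nc2cccc([N+](=O)[O-])c2)c2cc(Br)ccc2O1` gives 4000 nM, the lowest of the three numbers measured. Compound 2 `CC1(C)CC(NC(=S)Nc2cccc(Cl)c2)c2cc(Br)ccc2O1` gives 9000 nM, and compound 3 `COc1cccc(NC(=S)NC2CC(C)(C)Oc3ccc(Br)cc32)c1` gives 87000 nM. Compound 4 `CC1(C)CC(NC(=S)Nc2cccc([N+](=O)[O-])c2)c2cc(Cl)ccc2O1` is still unmeasured and differs from compound 1 by chloro in place of bromo on an aromatic carbon. Within the data shown here, no measured step touches this place. Elsewhere, chloro in place of nitro gave a 2.3-fold higher number from compound 1 to compound 2 (0.35 log units; beyond the scatter), and methoxy in place of nitro gave a 22-fold higher number from compound 1 to compound 3 (1.34 log units; beyond the scatter). These steps show that the numbers in this assay can move, but they do not size this swap, so no change beyond the scatter is expected. The expected step is a 1.3-fold higher number from compound 1 to compound 4 (0.10 log units; within the scatter). Compound 4 is estimated at 5000 nM, with an expected range of 2000 nM to 12000 nM.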

Compound 4, half-maximal inhibitory concentration: 4000 nM
For compound 4 the middle estimate is 1.3-fold (0.10 log units) above the measured one; measured number inside the range.
By their numbers in this assay, from the lowest: compounds 1 and 4 (each within the scatter of the next); then compound 2; then compound 3.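

In this assay, chloro in place of bromo gives no change at the digits printed from compound 1 to compound 4 (within the scatter) on the shared core that carries the nitro group. Among these compounds, this is the first reading at this position, and it shows that, with nitro in place, the two halogens cannot be told apart here, whereas the steps from nitro to chloro and to methoxy were beyond the scatter. Going by these compounds, whether an amine or a methoxy at this position would keep the number stays open, as does whether the halogen swap reads the same in compounds without the nitro group. Nothing available explains why the two halogens read alike.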